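The source may hold more compounds than are shown below. What is called first, only, known or untested is meant among the compounds shown, and "the series" means these compounds.

Working notes on the series. In a functional assay on A549 cells (Homo sapiens) for cytotoxicity, read by MTT assay, with a stated time of 72 h (on this read-out higher numbers stand for weaker inhibition and lower numbers for stronger inhibition), compound 1 (`N#Cc1ccc(/C=N/NC(=O)Nc2cc3c(Nc4ccc(F)c(Cl)c4)ncnc3cc2O[C@H]2CCOC2)cc1`) gives 29100 nM, compound 2 (`O=C(N/N=C/c1ccc([N+](=O)[O-])cc1)Nc1cc2c(Nc3ccc(F)c(Cl)c3)ncnc2cc1O[C@H]1CCOC1`) gives 31200 nM and compound 3 (`COc1cc2ncnc(Nc3ccc(F)c(Cl)c3)c2cc1NC(=O)N/N=C/c1ccc([N+](=O)[O-])cc1`) gives 35100 nM. These three values lie within the usual scatter of one another, so compound 3 stands level with compound 1 and compound 2, and no ranking can be drawn among them.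

The next compound is compound 4 (`COc1cc2ncnc(Nc3ccc(F)c(Cl)c3)c2cc1NC(=O)N/N=C/c1ccc(OC)c(OC)c1OC`). It keeps the rest of compound 3 and carries 2,3,4-trimethoxyphenyl in place of 4-nitrophenyl on a carbon with a double bond to nitrogen.

For the measured compounds named here, two measured steps bear on this. The nearer in kind, nitro in place of cyano on an aromatic carbon, is a 1.1-fold higher number from compound 1 to compound 2 (0.03 log units; within the scatter). The other, methyl in place of oxolan-3-yl on an oxygen on an aromatic ring, is a 1.1-fold higher number from compound 2 to compound 3 (0.05 log units; within the scatter). Neither moved the number beyond the scatter. Going by the values given here, no measured step exchanges the whole 4-nitrophenyl group, however, so the basis is thin and the range is kept wide.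

In this assay, no step beyond the scatter is expected, and the estimated step is a 1.2-fold lower number from compound 3 to compound 4 (0.07 log units; within the scatter). For compound 4 the expected value is 30000 nM, with an estimated range from 13000 nM to 60000 nM.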

Compound 4, half-maximal inhibitory concentration: 32800 nM
Compound 4: the middle estimate sits 1.1-fold (0.04 log units) below what was measured; the measured number falls inside the stated range.
By their numbers in this assay, from the lowest: compounds 1, 2, 4 and 3 (each within the scatter of the next).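

In this assay, 2,3,4-trimethoxyphenyl in place of 4-nitrophenyl on a carbon with a double bond to nitrogen gives a 1.1-fold lower number from compound 3 to compound 4 (0.03 log units; within the scatter). The earlier steps shown here changed only a single substituent on this aromatic ring or the group on the oxygen of the core, whereas this one exchanges the whole aryl group, and on the core of compound 3 that exchange still leaves the number within the scatter. No supporting measurement bears on what lies behind this result.

Still open, as far as these compounds go, is whether any group at this place can move the number beyond the scatter, for instance a phenyl ring carrying a dimethylamino group or a carboxylic acid, or a saturated piperidine ring in place of the phenyl ring. Also open, from the compounds shown here alone, is whether 2,3,4-trimethoxyphenyl gives a similar number when the oxygen of the core carries oxolan-3-yl, as in compound 1 and compound 2, rather than the methyl of compound 3 and compound 4.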